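Replacing tert-butyl by methyl: expected shift for compound 4

A few compounds are considered here, and "the series" means these few. Any claim that something is new, unique, unknown or untested is made for them only; others in the source may bear on it.

Compound 2 `CC(C)(C)c1[nH]cnc1/C=c1\[nH]c(=O)/c(=C/c2cccc(Oc3ccc(F)cc3)c2)[nH]c1=O` gives 4 nM in a functional assay on NCI-H460 cells (Homo sapiens) for cytotoxicity, read by MTT assay, with a stated time of 72 h; a lower number here means a stronger inhibitor, a higher number a weaker inhibitor. Compound 1 `CC(C)(C)c1[nH]cnc1/C=c1\[nH]c(=O)/c(=C/c2cccc(C(=O)c3ccc(F)cc3)c2)[nH]c1=O` carries (4-fluorophenyl)carbonyl where compound 2 has 4-fluorophenoxy. In this assay compound 1 gives 3.8 nM, and the step is a 1.1-fold higher number from compound 1 to compound 2 (0.02 log units; within the scatter). Compound 3 `O=c1[nH]/c(=C\c2nc[nH]c2C2CC2)c(=O)[nH]/c1=C\c1cccc(Oc2ccc(F)cc2)c1`, with cyclopropyl in place of tert-butyl, gives 15.2 nM; here a 3.8-fold higher number from compound 2 to compound 3 (0.58 log units; beyond the scatter). Compound 2 therefore sits second highest of the three numbers: indistinguishable from compound 1, and separated from compound 3 by a step beyond the scatter.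

Compound 4 `Cc1[nH]cnc1/C=c1\[nH]c(=O)/c(=C/c2cccc(Oc3ccc(F)cc3)c2)[nH]c1=O` has not been measured in this assay. It differs from compound 2 by methyl in place of tert-butyl on an aromatic carbon. Among the compounds with values here, only one measured step touches this aromatic carbon, a 3.8-fold higher number from compound 2 to compound 3 (0.58 log units; beyond the scatter), a modest loss. Within the data shown here, that step and the present change share the departure of tert-butyl from the same place, each with a single different entering group; no measured pair shows methyl there, so the size of the move is uncertain. The expectation is a step in the same direction as the cyclopropyl change, of comparable or somewhat larger size: a 5.0-fold higher number from compound 2 to compound 4 (0.70 log units; beyond the scatter). Compound 4 is thus estimated at 20 nM, with a range from 7 nM to 60 nM.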

Compound 4, half-maximal inhibitory concentration: 47.6 nM
For compound 4 the middle estimate is 2.4-fold (0.38 log units) below the measured one; the range from low to high includes it.
By their numbers in this assay, from the lowest: compounds 1 and 2 (each within the scatter of the next); then compound 3; then compound 4.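

In this assay, the loss on removing tert-butyl from this aromatic carbon of the five-membered ring depends strongly on the entering group: methyl gives a large step, a 12-fold higher number from compound 2 to compound 4 (1.08 log units; beyond the scatter), whereas cyclopropyl gave only a modest one. Cyclopropyl and methyl are also separated from each other, a 3.1-fold higher number from compound 3 to compound 4 (0.50 log units; beyond the scatter), so replacing tert-butyl does not produce a single common level of loss. Across compounds 2, 3 and 4, which share 4-fluorophenoxy, the numbers rise in the order tert-butyl, cyclopropyl, methyl, and none of these three compounds goes against that order, though no measurement available here accounts for it.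

On these data alone, it remains open where ethyl or isopropyl would fall in this order at the same carbon, and whether an aminomethyl group or a carboxylic acid there would fit it at all. The cyclopropyl and methyl changes are also shown only with 4-fluorophenoxy, so their size with the (4-fluorophenyl)carbonyl group of compound 1 is unknown.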